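Dropping a Fluorine from the Anilide of Compound 2

A few compounds are considered here, and "the series" means these few. Any claim that something is new, unique, unknown or untested is made for them only; others in the source may bear on it.

Measured compounds:
Compound 1 `O=C(CN1CCN(c2nnc(Cc3ccncc3)c3ccccc23)CC1)Nc1ccc(F)c(Cl)c1` gives 4 nM
Compound 2 `Cc1ccc(F)cc1NC(=O)CN1CCN(c2nnc(Cc3ccccc3)c3ccccc23)CC1` gives 19200 nM
Compound 3 `O=C(CN1CCN(c2nnc(Cc3ccccc3)c3ccccc23)CC1)Nc1ccc(F)c(F)c1` gives 2750 nM

In a functional assay on MDA-MB-231 cells (Homo sapiens) for cytotoxicity, read by MTT assay, with a stated time of 72 h (on this read-out higher numbers stand for weaker inhibition and lower numbers for stronger inhibition), compound 2 stands highest of the three numbers, meaning the weakest inhibition of the set. Its nearest neighbour is compound 3, reached by a 7.0-fold lower number from compound 2 to compound 3 (0.84 log units; beyond the scatter), a change in which the whole 5-fluoro-2-methylphenyl group is swapped for 3,4-difluorophenyl. Compound 1 lies much further away, but it differs from compound 2 at two places at once, so only the two values themselves can be compared.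

Compound 4 `Cc1ccccc1NC(=O)CN1CCN(c2nnc(Cc3ccccc3)c3ccccc23)CC1` is not yet measured. Against compound 2 the change is hydrogen in place of fluoro on an aromatic carbon, so 5-fluoro-2-methylphenyl becomes 2-methylphenyl. For the measured compounds named here, no measured step removes a single fluoro while leaving the rest of the group untouched, so none bears directly on it. Going by the values given here, the one change that touches this group, from compound 2 to compound 3, was modest and involved far more than a fluoro. For compound 4 the expected step is a 1.3-fold higher number from compound 2 to compound 4 (0.11 log units; within the scatter), which is not beyond the scatter. Compound 4 is therefore estimated at 25000 nM, within a range from 7000 nM to 90000 nM.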

Compound 4, half-maximal inhibitory concentration: 17300 nM
The estimate for compound 4 lay 1.4-fold (0.16 log units) above the measured number; measured number inside the range.
By their numbers in this assay, from the lowest: compound 1; then compound 3; then compounds 4 and 2 (each within the scatter of the next).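

In this assay, taking the fluoro off the aromatic carbon, so that 5-fluoro-2-methylphenyl becomes 2-methylphenyl, gives a 1.1-fold lower number from compound 2 to compound 4 (0.05 log units; within the scatter) and leaves the two compounds indistinguishable. The step from the 3,4-difluorophenyl amide is a 6.3-fold higher number from compound 3 to compound 4 (0.80 log units; beyond the scatter) and shows that the gap between compound 3 and the weaker pair remains without this fluoro, so this atom alone does not account for that gap. Nothing available here explains why the fluoro's removal changes so little.

A larger group at this place, such as methoxy, an amine or a carboxylic acid, remains untested in the compounds shown. Also open, from the compounds shown here alone, is whether removing a fluoro would matter as little in compound 3 or compound 1, whose anilide rings carry no methyl group.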